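Swapping the methoxyphenyl of compound 3 for a difluorophenyl

This account rests on a few compounds, and the source may have more. Where it says the series, first, only, none or still open, it means among the compounds named here.

Compound 3 `COc1ccc(C(=O)/C=C/c2cc(-c3cc(OC)c(OC)c(OC)c3)n[nH]2)cc1` gives -34% in a functional assay on A498 cells (Homo sapiens) for cytotoxicity, read by sulforhodamine B assay, with a stated time of 48 h, tested at 100 uM (a lower number here means a stronger effect, a higher number a weaker effect of the compound at the concentration tested), the second highest of three numbers. Its nearest neighbour is compound 2 `COc1cc(-c2cc(/C=C/C(=O)c3ccc(Cl)c(Cl)c3)[nH]n2)cc(OC)c1OC` with -25%; the step of a number 9 percentage points lower from compound 2 to compound 3 (within the scatter) stays within the scatter. Compound 1 `COc1cc(-c2cc(/C=C/C(=O)c3ccc(N)cc3)[nH]n2)cc(OC)c1OC` lies far off at -96%, and the step of a number 62 percentage points higher from compound 1 to compound 3 (beyond the scatter) is large. Compound 4 `COc1cc(-c2cc(/C=C/C(=O)c3ccc(F)c(F)c3)[nH]n2)cc(OC)c1OC` differs from compound 3 in one place: 3,4-difluorophenyl in place of 4-methoxyphenyl on a carbonyl carbon. Within the data shown here, the only step that bears on it is the exchange between compound 2 and compound 3, which was small, so a change of about the same size, near zero, is expected, giving an estimated a number 6 percentage points higher from compound 3 to compound 4 (within the scatter). Compound 4 is therefore expected to show -28% in this assay, between -50% and -5%.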

Compound 4, a percentage reported as activity, at one concentration (the size of the read-out at that concentration, not a potency): -40%
Compound 4: middle estimate off by 12 percentage points, on the high side, and the stated range covers the measured number.
By their numbers in this assay, from the lowest: compound 1; then compounds 4, 3 and 2 (each within the scatter of the next, the first and the last beyond it).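

In this assay, the step from 4-methoxyphenyl to 3,4-difluorophenyl on the carbonyl carbon is a number 6 percentage points lower from compound 3 to compound 4 (within the scatter), while the halogen exchange on the same ring gives a number 15 percentage points lower from compound 2 to compound 4 (beyond the scatter), a first sign that fluorine and chlorine at this place can be told apart. The 4-aminophenyl group stays apart from this new group too, with a number 56 percentage points higher from compound 1 to compound 4 (beyond the scatter). Nothing available explains these differences. Still open, as far as these compounds go, is whether the amine itself sets compound 1 apart, a question that 4-hydroxyphenyl or 4-(dimethylamino)phenyl at this carbonyl carbon would address.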